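The source may hold more compounds than are shown below. What is called first, only, known or untested is meant among the compounds shown, and "the series" means these compounds.

Measured compounds:
compound 1, `O=C1/C(=C\c2ccc(O)cc2)S/C(=N/c2ccccc2)N1Cc1ccncc1`, 11800 nM
compound 2, `O=C1/C(=C\c2ccc(Cl)cc2)S/C(=N/c2ccccc2)N1Cc1ccncc1`, 28800 nM
compound 3, `O=C1/C(=C\c2cccc(O)c2)S/C(=N/c2ccccc2)N1Cc1ccncc1`, 17600 nM

In a functional assay on HepG2 cells (Homo sapiens) for cytotoxicity, read by MTT assay, with a stated time of 48 h (a higher number here means a weaker inhibitor, a lower number a stronger inhibitor), compound 1 gives 11800 nM, compound 2 gives 28800 nM and compound 3 gives 17600 nM. Compound 2 differs from compound 1 by chloro in place of hydroxy on an aromatic carbon, and this change made a step of a 2.4-fold higher number from compound 1 to compound 2 (0.39 log units; beyond the scatter). Compound 3 differs from compound 1 by 3-hydroxyphenyl in place of 4-hydroxyphenyl on a double-bonded chain carbon bound to a double-bonded ring carbon; the values of compound 1 and compound 3 lie within the usual scatter of each other, as do those of compound 2 and compound 3.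

Compound 4, `O=C1/C(=C\c2cccc(Cl)c2)S/C(=N/c2ccccc2)N1Cc1ccncc1`, is not yet measured. It differs from compound 3 by chloro in place of hydroxy on an aromatic carbon. Going by the values given here, this is the same kind of change as the one from compound 1 to compound 2, but not the same: there the chloro sits para to a large group, here it sits meta to a large group. Among the compounds with values here, only one measured step of this kind exists, so the expectation for compound 4 rests on it alone. Compound 4 is expected to give a step of a 2.2-fold higher number from compound 3 to compound 4 (0.33 log units; beyond the scatter), in line with a 2.4-fold higher number from compound 1 to compound 2 (0.39 log units; beyond the scatter). Compound 4 is thus estimated at 38000 nM, with a likely range from 18000 nM to 80000 nM.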

Compound 4, half-maximal inhibitory concentration: 28900 nM
Compound 4: the middle estimate sits 1.3-fold (0.12 log units) above what was measured; measured number inside the range.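

In this assay, chloro in place of hydroxy gives a 1.6-fold higher number from compound 3 to compound 4 (0.22 log units; within the scatter), and set beside the earlier step, the change carries from one core to the other without a difference that can be told apart: the same change on two cores in this assay, a 2.4-fold higher number (0.39 log units; beyond the scatter) from compound 1 to compound 2 and a 1.6-fold higher number (0.22 log units; within the scatter) from compound 3 to compound 4, 1.5-fold (0.17 log units) apart, within the scatter of two such steps. The 3-chlorophenyl and 4-chlorophenyl compounds lie within the scatter of each other, with a 1.0-fold higher number from compound 2 to compound 4 (0.00 log units; within the scatter), while the step from the 4-hydroxyphenyl compound to the 3-chlorophenyl compound is a 2.4-fold higher number from compound 1 to compound 4 (0.39 log units; beyond the scatter). Going by these compounds alone, this shows that the two steps are compatible in this one assay, but with only two steps, the newer of them within the scatter, it fixes no size for the change and does not show that it would hold on any other core.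

From the compounds shown here alone, whether a methoxy group, an amine or a carboxylic acid in place of hydroxy would follow the same course remains open. So does the effect of changes elsewhere in the shared core, which stays the same in all four compounds.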